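This account rests on a few compounds, and the source may have more. Where it says the series, first, only, none or still open, it means among the compounds named here.

Measured so far in a functional assay on MCF7 cells (Homo sapiens) for antiproliferative activity, read by MTT assay, with a stated time of 48 h; on this read-out lower numbers stand for stronger inhibition and higher numbers for weaker inhibition:
- compound 1 `COc1ccc(-c2nnc(NC(=O)/C=C/c3ccc(C)cc3)s2)cc1`: 0.31 ug/mL
- compound 2 `COc1ccc(-c2nnc(NC(=O)/C=C/c3ccc(F)cc3)s2)cc1`: 0.85 ug/mL
- compound 3 `COc1ccc(-c2nnc(NC(=O)/C=C/c3ccccc3)s2)cc1`: 0.78 ug/mL

Compound 3 holds the second highest of the three numbers. Two gaps place it: (a 1.1-fold lower number from compound 2 to compound 3 (0.04 log units; within the scatter)) and (a 2.5-fold higher number from compound 1 to compound 3 (0.40 log units; beyond the scatter)).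

Compound 4 `O=C(/C=C/c1ccccc1)Nc1nnc(-c2ccc(Cl)cc2)s1` has chloro in place of methoxy on an aromatic carbon, para to a large group (chloro in place of methoxy on an aromatic carbon). The change reads 4-methoxyphenyl to 4-chlorophenyl. Among the measured compounds shown here, no measured step touches this site, so the evidence is only indirect. The three measured steps all exchange a group elsewhere in the molecule. Two of them, both losing the methyl of compound 1, were modest (a 2.7-fold higher number from compound 1 to compound 2 (0.44 log units; beyond the scatter)) and (a 2.5-fold higher number from compound 1 to compound 3 (0.40 log units; beyond the scatter)), while the third stayed within the scatter (a 1.1-fold lower number from compound 2 to compound 3 (0.04 log units; within the scatter)). None of them indicates a direction for the new change. In this assay a modest step at most is therefore expected, with neither direction favoured. The estimated step is a 1.0-fold higher number from compound 3 to compound 4 (0.01 log units; within the scatter), and a result within the scatter would fit this expectation. Compound 4 is estimated at 0.8 ug/mL, with an expected range of 0.3 ug/mL to 2.2 ug/mL.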

Compound 4, half-maximal inhibitory concentration: 1.42 ug/mL
For compound 4 the middle estimate is 1.8-fold (0.25 log units) below the measured one; measured number inside the range.
By their numbers in this assay, from the lowest: compound 1; then compounds 3, 2 and 4 (each within the scatter of the next).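

In this assay, among the compounds shown here, the change from 4-methoxyphenyl to 4-chlorophenyl gives a 1.8-fold higher number from compound 3 to compound 4 (0.26 log units; within the scatter) and is the first direct reading at this site, as all earlier steps lay on the other aromatic ring. Methoxy, with its hydrogen-bond acceptor, can thus give way to chloro, which has none, without a step beyond the scatter, so this one exchange shows no firm dependence of the read-out on either group here. The data offer no explanation for this outcome.

As far as these compounds go, whether an amine, a carboxylic acid, hydrogen or a longer chain such as butoxy at this position would stay equally close remains open. Also open, from the compounds shown here alone, is whether the methyl on the other ring, which sets compound 1 apart, would have the same effect alongside chloro.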